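Swapping One Side Chain on Compound 1

This account rests on a few compounds, and the source may have more. Where it says the series, first, only, none or still open, it means among the compounds named here.

In an ADME assay on S9 fraction from liver (Homo sapiens) for metabolic stability, read by LC-MS, using NADPH, with stated times of 5 min and 60 min, tested at 5 uM (a lower number here means that less of the compound is left, a higher number that more of the compound is left), compound 1 (`COc1cc(C2CN(C(=O)c3cc(OC[C@@H](O)CO)ccn3)C2)ccc1OCc1ccc(C2CC2)cc1`) gives 63% and compound 2 (`CCc1ccc(COc2ccc(C3CN(C(=O)c4cc(COCC(CO)(CO)CO)ccn4)C3)cc2OC)cc1`) gives 61% on the same scale. These two values lie within the scatter of each other, so compound 1 has no measured neighbour clearly apart from it.

Compound 3 (`COc1cc(C2CN(C(=O)c3cc(COCC(CO)CO)ccn3)C2)ccc1OCc1ccc(C2CC2)cc1`), not yet measured, differs from compound 1 in one place, on an aromatic carbon of a six-membered aromatic ring with 1 nitrogen, meta to a large group and opposite the ring nitrogen. There, (3-hydroxy-2-(hydroxymethyl)propoxy)methyl comes in place of 2,3-dihydroxypropoxy ((3-hydroxy-2-(hydroxymethyl)propoxy)methyl in place of 2,3-dihydroxypropoxy on an aromatic carbon). Among the measured compounds shown here, no two measured compounds differ in only one place, so the data hold no direct measure of such a swap. For the measured compounds named here, the only guide is that compound 1 at 63% and compound 2 at 61% sit close together, so no step beyond the scatter is expected in this assay and neither direction is favoured. The estimated change is a number 3 percentage points lower from compound 1 to compound 3 (within the scatter) and that lies within the scatter. For compound 3 the expected value is 60% with an estimated range from 44% to 76% around it.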

Compound 3, percent of the compound remaining: 55%
Beside the measured number, compound 3's estimate is 5 percentage points above it; measured number inside the range.
By their numbers in this assay, from the lowest: compounds 3, 2 and 1 (each within the scatter of the next).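

Among the compounds shown here, this is the first direct measure of a swap at this position, on an aromatic carbon opposite the ring nitrogen: in this assay, putting (3-hydroxy-2-(hydroxymethyl)propoxy)methyl in place of 2,3-dihydroxypropoxy gives a number 8 percentage points lower from compound 1 to compound 3 (within the scatter) as its step. The assay therefore does not tell these two side chains apart, even though the entering chain has 8 heavy atoms against 6 and no defined stereocentre against 1, while both chains have 2 hydrogen-bond donors and 3 hydrogen-bond acceptors. No measurement is available to explain where the number falls.

Still open, from the compounds shown here alone, is whether a side chain of another kind at this position, such as an amine, a carboxylic acid or a longer chain, would give a step beyond the scatter. A single pair also leaves open whether this same swap would read alike on a core other than that of compound 1, or in a different assay.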